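Oxolane amide to difluorophenyl amide on the shared core

The source may hold more compounds than are shown below. What is called first, only, known or untested is meant among the compounds shown, and "the series" means these compounds.

Compound 3 `Cc1cc(NC(=O)C2CCCO2)nn1Cc1cc(Cl)ccc1OCc1ccccc1` gives 39.8 nM in an assay on CHO-K1 cells for displacement of a labelled ligand from prostaglandin E2 receptor EP1 subtype (Homo sapiens) (on this read-out higher numbers stand for weaker inhibition and lower numbers for stronger inhibition), level with compound 2 `Cc1cc(C(=O)NCc2ccccc2)nn1Cc1cc(Cl)ccc1OCc1ccccc1` at 39.8 nM and, together with it, the lowest of the three numbers; compound 1 `Cc1cc(C(=O)Nc2cccc(F)c2)nn1Cc1cc(Cl)ccc1OCc1ccccc1` gives 200 nM. Compound 4 `Cc1cc(NC(=O)c2c(F)cccc2F)nn1Cc1cc(Cl)ccc1OCc1ccccc1` differs from compound 3 in one place: 2,6-difluorophenyl in place of oxolan-2-yl on a carbonyl carbon. Within the data shown here, no measured step covers this exchange directly. The two steps that involve an aryl group, a 5.0-fold lower number from compound 1 to compound 2 (0.70 log units; beyond the scatter) and a 5.0-fold lower number from compound 1 to compound 3 (0.70 log units; beyond the scatter), both show the number falling when the aryl group gives way to another group, while no change at the digits printed from compound 2 to compound 3 (within the scatter) shows none. Because compound 1 carrying a fluorinated aryl group gives 200 nM, the return of an aryl group is expected to raise the number. The step is estimated as a 2.0-fold higher number from compound 3 to compound 4 (0.30 log units; within the scatter). Compound 4 is expected at 80 nM, within a range of 25 nM to 250 nM.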

Compound 4, half-maximal inhibitory concentration: 12.6 nM
Compound 4: middle estimate off by 6.3-fold (0.80 log units), on the high side; the measured number lies below the stated range.
By their numbers in this assay, from the lowest: compound 4; then compounds 2 and 3 (each within the scatter of the next); then compound 1.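

On the carbonyl carbon, 2,6-difluorophenyl in place of oxolan-2-yl gives a 3.2-fold lower number from compound 3 to compound 4 (0.50 log units; beyond the scatter) in this assay and shows that an aryl group at this position can go with a lower number than the groups before it. The ((2,6-difluorophenyl)carbonyl)amino group also gives a 3.2-fold lower number from compound 2 to compound 4 (0.50 log units; beyond the scatter) and a 16-fold lower number from compound 1 to compound 4 (1.20 log units; beyond the scatter) as the largest step in this set. No measurement shown accounts for these steps. From the compounds shown here alone, it remains open whether the fluorines are needed, since plain phenyl does not appear here, and how a pyridine ring or a carboxylic acid on the ring would read.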